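Second Fluorine Added Beside the Single-Fluoro Benzyl Arm

A few compounds are considered here, and "the series" means these few. Any claim that something is new, unique, unknown or untested is made for them only; others in the source may bear on it.

Compound 3 `O=C(O)c1ccccc1-c1ccc(CCc2ncc(Cc3ccc(F)cc3)[nH]2)cc1` stands second highest of the three measured values in an in vitro functional assay on cells for agonist activity at Bombesin receptor subtype-3 (Homo sapiens), read by luminescence and calcium flux (a higher number here means that more compound is needed for the effect, a lower number that less compound is needed), where compound 3 gives 1600 nM. Compound 1 `COc1ccc(Cc2cnc(CCc3ccc(-c4ccccc4C(=O)O)cc3)[nH]2)cc1` is its nearest neighbour; in this assay compound 1 gives 5360 nM, and the step of a 3.4-fold lower number from compound 1 to compound 3 (0.53 log units; beyond the scatter) is modest. Compound 2 `O=C(O)c1ccccc1-c1ccc(CCc2ncc(Cc3ccccc3F)[nH]2)cc1` lies furthest off; in this assay compound 2 gives 177 nM, reached through a 30-fold lower number from compound 1 to compound 2 (1.48 log units; beyond the scatter) from compound 1 and separated from compound 3 by a 9.0-fold higher number from compound 2 to compound 3 (0.96 log units; beyond the scatter). Compound 4 `O=C(O)c1ccccc1-c1ccc(CCc2ncc(Cc3cccc(F)c3F)[nH]2)cc1` has not yet been measured. Its change from compound 3 is 2,3-difluorophenyl in place of 4-fluorophenyl on a saturated chain carbon bound to an aromatic carbon. The 2,3-difluorophenyl of compound 4 contains the 2-fluoro substitution that compound 2 carries as 2-fluorophenyl, so the step of a 9.0-fold higher number from compound 2 to compound 3 (0.96 log units; beyond the scatter) bears most directly on it; the second fluorine of the 2,3-difluorophenyl has no measured precedent among these compounds. Because the step of a 9.0-fold higher number from compound 2 to compound 3 (0.96 log units; beyond the scatter) was modest, compound 4 is expected to show a step of a 5.3-fold lower number from compound 3 to compound 4 (0.73 log units; beyond the scatter) in this assay, recovering most of the distance toward compound 2. The estimate for compound 4 is 300 nM, with a range from 100 nM to 1000 nM.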

Compound 4, half-maximal effective concentration: 87 nM
Beside the measured number, compound 4's estimate is 3.4-fold (0.54 log units) above it; the measured number lies below the stated range.
By their numbers in this assay, from the lowest: compound 4; then compound 2; then compound 3; then compound 1.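

In this assay the 2,3-difluorophenyl on a saturated chain carbon bound to an aromatic carbon gives the lowest number of the four compounds, with an 18-fold lower number from compound 3 to compound 4 (1.26 log units; beyond the scatter) and a 62-fold lower number from compound 1 to compound 4 (1.79 log units; beyond the scatter) as large steps. The earlier compounds shown here compared only single substituents on this ring, whereas compound 4 shows that a second fluorine can be added to the 2-fluorophenyl of compound 2 without losing its low number. Fluoro in place of hydrogen on an aromatic carbon gives a 2.0-fold lower number from compound 2 to compound 4 (0.31 log units; beyond the scatter) and this modest step is the only one here that isolates the added fluorine.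

The compounds shown leave open whether chloro or trifluoromethyl in place of that added fluorine would give a still lower number. No measurement in hand accounts for any of these steps.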